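Swapping ethyl for acetyl on the piperazine nitrogen

The compounds below may be only part of what the source reports. "The series", "measured", "known", "first", "only" and "open" are said of these compounds alone.

Compound 1 `COc1ccc(CN(C(=O)CSC(=S)N2CCN(C(=O)OC(C)(C)C)CC2)c2cc(OC)c(OC)c(OC)c2)cc1O`: 82 nM
Compound 2 `CCN1CCN(C(=S)SCC(=O)N(Cc2ccc(OC)c(O)c2)c2cc(OC)c(OC)c(OC)c2)CC1`: 380 nM

Both values come from a functional assay on MGC-803 cells (Homo sapiens) for inhibition, read by CCK-8 assay, with a stated time of 48 h (on this read-out lower numbers stand for stronger inhibition and higher numbers for weaker inhibition), and compound 2 holds the higher of the two numbers, at 380 nM in this pair. Compound 3 `COc1ccc(CN(C(=O)CSC(=S)N2CCN(C(C)=O)CC2)c2cc(OC)c(OC)c(OC)c2)cc1O` has not yet been measured. It carries acetyl in place of ethyl on an amine nitrogen in a ring, (acetyl in place of ethyl on an amine nitrogen in a ring), a difference that also reads 4-ethylpiperazin-1-yl to 4-acetylpiperazin-1-yl. Going by the values given here, one measured step bears on this same ring nitrogen, a 4.6-fold higher number from compound 1 to compound 2 (0.67 log units; beyond the scatter), with ethyl in place of tert-butoxycarbonyl. That step is modest but lies beyond the scatter. Among the compounds with values here, it is a single pair and shows no general pattern, and no measured compound yet carries acetyl. Within the data shown here, still, acetyl, like tert-butoxycarbonyl, brings a carbonyl onto that nitrogen where ethyl has none, so a move towards a lower number is expected, probably no larger than the one seen with compound 1. The expected size is a 2.4-fold lower number from compound 2 to compound 3 (0.38 log units; beyond the scatter), in that direction. For compound 3 the estimated value is 160 nM, with an expected range from 60 nM to 420 nM.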

Compound 3, half-maximal inhibitory concentration: 310 nM
Compound 3: the middle estimate sits 1.9-fold (0.29 log units) below what was measured, and the stated range covers the measured number.
By their numbers in this assay, from the lowest: compound 1; then compounds 3 and 2 (each within the scatter of the next).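

In this assay, compound 2 and compound 3 read alike (a 1.2-fold lower number from compound 2 to compound 3 (0.09 log units; within the scatter)), so at this ring nitrogen the entry of acetyl, with its carbonyl and hydrogen-bond acceptor, does not separate the pair. With methyl in place of tert-butoxy on a carbonyl carbon, the difference from compound 1 remains beyond the scatter (a 3.8-fold higher number from compound 1 to compound 3 (0.58 log units; beyond the scatter)), which shows that a carbonyl on this nitrogen is not enough to give the low number of compound 1. Among these three compounds, only compound 1 with its tert-butoxycarbonyl stands apart, and no available evidence explains why.

The compounds shown leave open which part of tert-butoxycarbonyl matters, since methoxycarbonyl would keep the oxygen on the carbonyl carbon without the tert-butyl, while pivaloyl would keep the tert-butyl without that oxygen. They also leave open how this position would read with an unsubstituted ring amine or a benzyl group on the nitrogen, and whether the pattern among these three compounds would hold for other substituents.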